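This account rests on a few compounds, and the source may have more. Where it says the series, first, only, none or still open, it means among the compounds named here.

Compound 1 `Nc1ccccc1NC(=O)/C=C/c1ccc(CSc2ccc(Cl)cc2)cc1` was tested in a functional assay on SMMC-7721 cells (Homo sapiens) for inhibition, read by CCK-8 assay, with a stated time of 72 h, tested at 2 uM (on this read-out higher numbers stand for more inhibition of growth at the one concentration tested and lower numbers for less inhibition of growth), where compound 1 gives 15.2%. Alongside it stands compound 2 `CC(C)(C)c1ccc(SCc2ccc(C(=O)Nc3ccccc3N)cc2)cc1`, which in this assay gives 23.6%. Compound 1 holds the lower of these two numbers, but the gap to compound 2 lies within the usual scatter of such measurements, so the two cannot be told apart. The next compound, compound 3 `CCc1ccc(SCc2ccc(/C=C/C(=O)Nc3ccccc3N)cc2)cc1`, has not yet been measured in this assay. It differs from compound 1 in a single place: ethyl in place of chloro on an aromatic carbon. Among the measured compounds shown here, the shared core stays the same; only this one group changes. For the measured compounds named here, no pair of measured compounds shows what such an exchange does, so no measured step can guide the expectation. Given that compound 1 reaches only 15.2%, the step of a number 2.8 percentage points higher from compound 1 to compound 3 (within the scatter) is expected to stay within the scatter, in either direction. On that basis compound 3 is expected to give about 18%, within a range from 5% to 32%.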

Compound 3, percent growth inhibition at one concentration: 13.2%
Compound 3: middle estimate off by 4.8 percentage points, on the high side, within the range that was stated.
By their numbers in this assay, from the lowest: compounds 3, 1 and 2 (each within the scatter of the next, the first and the last beyond it).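

Putting ethyl in place of chloro on an aromatic carbon, para to a large group, gives a number 2 percentage points lower from compound 1 to compound 3 (within the scatter) in this assay. Among the compounds shown here, this is the first measured exchange at this position, and it shows that 4-chlorophenyl and 4-ethylphenyl cannot be told apart on this read-out, even though the group goes from 1 heavy atom to 2 heavy atoms. Nothing measured here offers an explanation for this result.

On these data alone, whether a group of another kind at this position, such as an amine, a carboxylic acid or a longer chain, would move the number beyond the scatter remains open. Also open, as far as these compounds go, is whether this exchange would give a similar step on another core, since it is seen here in a single pair of compounds.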